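The source may report more compounds than this note shows. Statements on the series, on what has been measured and on what is new or still open speak of the compounds shown alone.

Measured so far in a functional assay on CNE-2 cells (Homo sapiens) for cytotoxicity, read by MTT assay, with a stated time of 72 h; on this read-out lower numbers stand for stronger inhibition and higher numbers for weaker inhibition:
Compound 1, `COc1ccccc1C(=O)NC(=S)NNc1ncnc2ccccc12`, gives 15700 nM
Compound 2, `O=C(NC(=S)NNc1ncnc2ccccc12)c1ccccc1`, gives 1490 nM
Compound 3, `O=C(NC(=S)NNc1ncnc2ccccc12)c1ccc(Cl)cc1`, gives 1530 nM

Compound 3 stands second highest of the three numbers; the nearest step is a 1.0-fold higher number from compound 2 to compound 3 (0.01 log units; within the scatter), the furthest a 10-fold lower number from compound 1 to compound 3 (1.01 log units; beyond the scatter).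

Compound 4, `O=C(NC(=S)NNc1ncnc2ccccc12)c1ccccc1Cl`, has not been measured. Its change from compound 3 is 2-chlorophenyl in place of 4-chlorophenyl on a carbonyl carbon. For the measured compounds named here, two steps bear on this. Adding chlorine elsewhere on the ring changed little: a 1.0-fold higher number from compound 2 to compound 3 (0.01 log units; within the scatter). But compound 1, which carries a 2-methoxyphenyl in the same place where the 2-chlorophenyl now enters, gave the weakest result, and an 11-fold lower number from compound 1 to compound 2 (1.02 log units; beyond the scatter). A rise in the number, smaller than that, is therefore expected. Compound 4 is expected to give about 3500 nM (range 1300 nM to 10000 nM), an expected step of a 2.3-fold higher number from compound 3 to compound 4 (0.36 log units; beyond the scatter).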

Compound 4, half-maximal inhibitory concentration: 6090 nM
Compound 4: the middle estimate sits 1.7-fold (0.24 log units) below what was measured, and the stated range covers the measured number.
By their numbers in this assay, from the lowest: compounds 2 and 3 (each within the scatter of the next); then compound 4; then compound 1.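

In this assay, the same atoms joined differently change the result: 2-chlorophenyl in place of 4-chlorophenyl gives a 4.0-fold higher number from compound 3 to compound 4 (0.60 log units; beyond the scatter), and chloro in place of hydrogen now gives a 4.1-fold higher number from compound 2 to compound 4 (0.61 log units; beyond the scatter), although the same swap in 4-chlorophenyl stayed within the scatter. The group itself also counts, since chloro in place of methoxy gives a 2.6-fold lower number from compound 1 to compound 4 (0.41 log units; beyond the scatter). Nothing measured here explains these differences. As far as these compounds go, it remains open how an amine, a carboxylic acid or a longer chain in place of the chloro would read.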